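Replacing the oxazolyl of compound 3 with a methoxy group

A few compounds are considered here, and "the series" means these few. Any claim that something is new, unique, unknown or untested is made for them only; others in the source may bear on it.

Compound 3 `c1cc(-c2ncco2)c2c(c1)C(c1ncc[nH]1)CC2` gives 170 nM in a functional assay on CHO cells for agonist activity at Alpha-1A adrenergic receptor (Homo sapiens), read by FLIPR and calcium flux (a higher number here means that more compound is needed for the effect, a lower number that less compound is needed), the lowest of the three numbers measured. Compound 2 `c1cc(-c2nccs2)c2c(c1)C(c1ncc[nH]1)CC2` gives 426 nM, and compound 1 `CCCS(=O)(=O)Nc1cccc2c1CCC2c1ncc[nH]1` gives 1340 nM; the step of a 2.5-fold lower number from compound 2 to compound 3 (0.40 log units; beyond the scatter) and the step of a 7.9-fold lower number from compound 1 to compound 3 (0.90 log units; beyond the scatter) are both beyond the scatter, so compound 3 is the most potent of the three. Compound 4 `COc1cccc2c1CCC2c1ncc[nH]1` differs from compound 3 in one place: methoxy in place of 1,3-oxazol-2-yl on an aromatic carbon. For the measured compounds named here, no measured step swaps a five-membered aromatic ring for a group without a ring at this position, but the step of a 7.9-fold lower number from compound 1 to compound 3 (0.90 log units; beyond the scatter) shows that the only measured compound with a non-ring group here, compound 1, gives the highest number, and the step of a 3.1-fold lower number from compound 1 to compound 2 (0.50 log units; beyond the scatter) shows that the other ring also sits below it. A modest rise is therefore expected for compound 4, a 4.7-fold higher number from compound 3 to compound 4 (0.67 log units; beyond the scatter), with wide uncertainty. Compound 4 is estimated at 800 nM, within 250 nM to 2500 nM.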

Compound 4, half-maximal effective concentration: 32 nM
The estimate for compound 4 lay 25-fold (1.40 log units) above the measured number; measured number outside the range, below it.
By their numbers in this assay, from the lowest: compound 4; then compound 3; then compound 2; then compound 1.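

In this assay a five-membered aromatic ring turns out not to be needed for a low number on this aromatic carbon, since methoxy, which has no ring, gives a 5.3-fold lower number from compound 3 to compound 4 (0.73 log units; beyond the scatter) against the oxazolyl compound and a 13-fold lower number from compound 2 to compound 4 (1.12 log units; beyond the scatter) against the thiazolyl compound. The high number of compound 1 therefore does not speak for groups without a ring in general. The two ring-free groups themselves stand furthest apart, with a 42-fold lower number from compound 1 to compound 4 (1.62 log units; beyond the scatter) on the same aromatic carbon, so the choice among such groups matters more here than the choice between the two rings.

Going by these compounds, whether a hydroxyl, an ethoxy or an amine on this carbon would keep or lower the number remains open. The data offer no explanation for the low number of compound 4.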